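Nitro Variant of a Prostacyclin Synthase Inhibitor

A few compounds are considered here, and "the series" means these few. Any claim that something is new, unique, unknown or untested is made for them only; others in the source may bear on it.

Of the compounds shown here, two have been measured in an assay for inhibition of prostacyclin synthase (Homo sapiens), using microsomes; on this read-out higher numbers stand for weaker inhibition and lower numbers for stronger inhibition. Compound 1 `CC(C)(Oc1ccc(F)cc1)C1OCC(C/C=C\CCC(=O)O)C(c2cccnc2)O1` gives 2000 nM in this assay. Compound 2 `COc1ccccc1OC(C)(C)C1OCC(C/C=C\CCC(=O)O)C(c2cccnc2)O1`, with 2-methoxyphenyl in place of 4-fluorophenyl on an oxygen on a saturated carbon, gives 51000 nM, the highest of the two numbers and the weaker inhibitor. Within the data shown here, the one step that connects them, a 26-fold higher number from compound 1 to compound 2 (1.41 log units; beyond the scatter), is a large rise.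

Compound 3 `CC(C)(Oc1ccc(F)cc1[N+](=O)[O-])C1OCC(C/C=C\CCC(=O)O)C(c2cccnc2)O1` is the next variant: 4-fluoro-2-nitrophenyl in place of 2-methoxyphenyl on an oxygen on a saturated carbon. This change brings back the fluorine that compound 1 carries while a nitro group now takes the place held by methoxy. Since the step from compound 1 to compound 2 was large, returning the fluorine is expected to pull the number part of the way back, so an 8.5-fold lower number from compound 2 to compound 3 (0.93 log units; beyond the scatter) is the estimated step, in the direction of stronger inhibition. Compound 3 is therefore expected to give about 6000 nM in this assay, within roughly 1500 nM to 25000 nM.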

Compound 3, half-maximal inhibitory concentration: 9000 nM
Beside the measured number, compound 3's estimate is 1.5-fold (0.18 log units) below it, within the range that was stated.
By their numbers in this assay, from the lowest: compound 1; then compound 3; then compound 2.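

Nitro in place of hydrogen on an aromatic carbon gives a 4.5-fold higher number from compound 1 to compound 3 (0.65 log units; beyond the scatter), so with the fluorine kept, this one added group goes with weaker inhibition. 4-fluoro-2-nitrophenyl in place of 2-methoxyphenyl gives a 5.7-fold lower number from compound 2 to compound 3 (0.75 log units; beyond the scatter), which shows that the group on this oxygen can also move the number down, although compound 1 still has the lowest number of the three. That second step swaps two ring substituents at once, so it cannot show how much of the drop goes with the fluorine and how much with the nitro group, and no supporting data explain either step.

Going by these compounds, it remains open how an amine or a nitrile would compare with nitro on this ring. On these data alone, the number for plain 2-nitrophenyl, without the fluorine, also remains open.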